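Adding a Chloro Group to Compound 2

This account rests on a few compounds, and the source may have more. Where it says the series, first, only, none or still open, it means among the compounds named here.

Of the compounds shown here, two sharing one core have been measured in a functional assay on the whole organism for positive allosteric modulation, with Mus musculus as the target; on this read-out higher numbers stand for an effect only at larger amounts of compound and lower numbers for an effect already at smaller amounts. Compound 1, `CCC(=O)N(c1ccc(C)cc1)C1CCCC1N(C)C`, gives 30 mg/kg; 30 mg/kg (2 entries) in both of its entries. Compound 2, `CCC(=O)N(c1ccc(F)cc1)C1CCCC1N(C)C`, gives 5 mg/kg, the lower of the two values, so it responds at the smaller dose. Compound 3, `CCC(=O)N(c1ccc(F)c(Cl)c1)C1CCCC1N(C)C`, is compound 2 with chloro in place of hydrogen on an aromatic carbon, (chloro in place of hydrogen on an aromatic carbon). Among the measured compounds shown here, no measured step in this assay shows what such a replacement does, so the expectation starts from compound 2 at 5 mg/kg and remains uncertain. The expected change is small, within the usual scatter and without a firm direction, and the estimated step is a 1.3-fold lower number from compound 2 to compound 3 (0.10 log units; within the scatter). Compound 3 is estimated at 4 mg/kg, with an expected range from 1.3 mg/kg to 15 mg/kg.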

Compound 3, dose for half-maximal effect: 0.2 mg/kg
Beside the measured number, compound 3's estimate is 20-fold (1.30 log units) above it, outside the stated range (below it).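

In this assay, placing a chloro group on the aromatic ring, ortho to a fluoro group and meta to a large group, gives a 25-fold lower number from compound 2 to compound 3 (1.40 log units; beyond the scatter). Among the compounds shown here, compound 1 and compound 2 carry no group at this place, so this single added heavy atom is the first sign that the place strongly affects the dose needed, a step well beyond the usual scatter. No measurement given here accounts for a step of this size.

The compounds shown leave open whether the effect is specific to chloro or would also appear with bromo, methyl or methoxy at the same place. They also leave open whether it depends on the neighbouring fluoro group, or would persist with the methyl group that compound 1 carries in its stead.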